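The compounds below may be only part of what the source reports. "The series", "measured", "known", "first", "only" and "open" are said of these compounds alone.

Of the compounds shown here, two have so far been measured in an assay on isolated protein for inhibition of serine/threonine-protein kinase TNNI3K (Homo sapiens); on this read-out lower numbers stand for stronger inhibition and higher numbers for weaker inhibition. Compound 1 `CNc1cc(Oc2ccc(NC(=O)Nc3cccc(C)c3)cc2)ncn1` gives 1260 nM. Compound 2 `O=C(Nc1ccc(Oc2ccncn2)cc1)Nc1cccc(C(F)(F)F)c1` gives 160 nM, the lowest of the two numbers, and the gap to compound 1 lies beyond the usual scatter.

Compound 3 `CNc1cc(Oc2ccc(NC(=O)Nc3cccc(C(F)(F)F)c3)cc2)ncn1` has not been measured. It differs from compound 2 by methylamino in place of hydrogen on an aromatic carbon. Among the measured compounds shown here, no measured pair shows this change on its own, so its effect is unknown. The expected step in this assay is a 1.3-fold higher number from compound 2 to compound 3 (0.10 log units; within the scatter), nothing beyond the scatter. Compound 3 is therefore estimated at 200 nM, within a range from 60 nM to 700 nM.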

Compound 3, half-maximal inhibitory concentration: 40 nM
Compound 3: middle estimate off by 5.0-fold (0.70 log units), on the high side; measured number below the stated range.
By their numbers in this assay, from the lowest: compound 3; then compound 2; then compound 1.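

Placing methylamino on the aromatic carbon that carries only hydrogen in compound 2 gives a 4.0-fold lower number from compound 2 to compound 3 (0.60 log units; beyond the scatter) in this assay, so this position accepts the group and the number falls. With methylamino kept, trifluoromethyl in place of methyl on an aromatic carbon gives a 32-fold lower number from compound 1 to compound 3 (1.50 log units; beyond the scatter) and shows that this second change also counts when methylamino is present. Nothing measured here explains either step.

From the compounds shown here alone, it remains open whether a plain amino group, dimethylamino or a longer chain such as ethylamino would act like methylamino at this carbon. Going by these compounds, the effect of a methoxy group there is also open.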